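The source may hold more compounds than are shown below. What is called first, only, known or untested is meant among the compounds shown, and "the series" means these compounds.

In a functional assay on 1321-N1 cells for agonist activity at Free fatty acid receptor 1 (Homo sapiens), read by calcium flux (a higher number here means a larger maximal response, a lower number a smaller maximal response), three compounds have been measured so far. Compound 1, `O=C(O)CCc1ccc(C#Cc2ccccc2)cc1`, gives 108%. Compound 2, `N#Cc1cccc(COc2ccc(CCC(=O)O)cc2)c1`, gives 102%. Compound 3, `O=C(O)CCc1ccc(NCc2cccc(C(F)(F)F)c2)cc1`, gives 102%. All three reach a maximal response close to that of the control, so each behaves as a full agonist in this setting.

Compound 2 stands level with compound 3 at the digits shown, and these two together hold the lowest of the three numbers; compound 1 lies above them by a margin that stays within the usual scatter, so no real order can be read among the three.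

Compound 4, `COc1ccccc1-c1cccc(COc2ccc(CCC(=O)O)cc2)c1`, is the one not yet measured. It differs from compound 2 in a single place: 2-methoxyphenyl in place of cyano on an aromatic carbon. The change sits on an aromatic carbon of a six-membered aromatic ring of carbon only, meta to a large group.

Within the data shown here, no pair of measured compounds differs in only one place, so no measured step guides this change directly. Still, the maximal response is expected to stay put, because compound 1 with 108% and compound 3 with 102% carry quite different end groups yet sit at the same level as compound 2. The step of a number 2 percentage points lower from compound 2 to compound 4 (within the scatter) is expected to be none beyond the scatter. Compound 4 is therefore estimated to give 100%, within a range from 85% to 115%.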

Compound 4, largest response reached (reported as efficacy), in percent of the reference or control that the assay uses: 105%
For compound 4 the middle estimate is 5 percentage points below the measured one; the range from low to high includes it.
By their numbers in this assay, from the lowest: compounds 2, 3, 4 and 1 (each within the scatter of the next).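

In this assay, among these compounds, putting 2-methoxyphenyl in place of cyano on this aromatic carbon gives a number 3 percentage points higher from compound 2 to compound 4 (within the scatter), the first measured step between two compounds that differ in only one place. The entering group has 8 heavy atoms against 2 for cyano and brings a whole six-membered aromatic ring, yet the maximal response shows no change beyond the scatter, so at this position, meta to a large group, a far bulkier substituent still gives a full response. Nothing shown explains why the response holds steady at this position.

This single step cannot say whether the position tolerates any group, and a plain phenyl, an amine or a carboxylic acid on the same carbon could each behave differently from 2-methoxyphenyl. The largest response reached also says nothing about the concentration needed to reach it, so compound 2 and compound 4 could still differ in that respect even though they match on this read-out.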